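Clearance Notes: Aminopyridine Sulfone Series, Compound 3 to 4

The source may report more compounds than this note shows. Statements on the series, on what has been measured and on what is new or still open speak of the compounds shown alone.

Measured compounds:
compound 1 `CC#Cc1cc(C(O)(C(F)(F)F)C(F)(F)F)cnc1-c1ccc(S(=O)(=O)c2ccc(N)nc2)cc1`: 177 mL.min-1.g-1
compound 2 `Nc1ccc(S(=O)(=O)c2ccc(-c3ncc(C(O)(C(F)(F)F)C(F)(F)F)cc3C#CCO)cc2)cn1`: 36 mL.min-1.g-1
compound 3 `CNc1nc(S(=O)(=O)c2ccc(N)nc2)ccc1-c1ccc(C(C)(O)C(F)(F)F)cn1`: 21 mL.min-1.g-1

In an ADME assay (liver) for metabolic stability, with Liver microsome (Rattus norvegicus) as the target, using microsomes and NADPH, with a stated time of 30 min, at 37 degrees C, tested at 1 uM (on this read-out higher numbers stand for fast clearance and lower numbers for slow clearance), compound 3 gives the lowest of the three numbers; its gap to compound 2 is within the scatter, while compound 1 sits beyond the scatter above it. For the measured compounds named here, the only measured step, a 4.9-fold lower number from compound 1 to compound 2 (0.69 log units; beyond the scatter), concerns a hydroxy on a chain at a triple bond and does not touch the amine nitrogen. Compound 4 `CC(O)(c1ccc(-c2ccc(S(=O)(=O)c3ccc(N)nc3)nc2Nc2ccccn2)nc1)C(F)(F)F` differs from compound 3 by pyridin-2-yl in place of methyl on a nitrogen on an aromatic ring. Going by the values given here, no measured step bears on this change, so the expectation rests on compound 3 alone with a wide range. Compound 4 is estimated at 30 mL.min-1.g-1 (range 12 mL.min-1.g-1 to 75 mL.min-1.g-1), an expected step of a 1.4-fold higher number from compound 3 to compound 4 (0.15 log units; within the scatter), not beyond the scatter.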

Compound 4, intrinsic clearance in microsomes: 130 mL.min-1.g-1
For compound 4 the middle estimate is 4.3-fold (0.64 log units) below the measured one; the whole stated range lies below it.
By their numbers in this assay, from the lowest: compounds 3 and 2 (each within the scatter of the next); then compounds 4 and 1 (each within the scatter of the next).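

In this assay, for the compounds shown here, the nitrogen on the aromatic ring does not tolerate every substituent equally: methylamino to (pyridin-2-yl)amino gives a 6.2-fold higher number from compound 3 to compound 4 (0.79 log units; beyond the scatter) as the first measured step at this position. The earlier compounds shown here carried only methyl here, so they gave no reading of how clearance responds to a change on this nitrogen. The data shown offer no measured explanation for this step.

From the compounds shown here alone, whether the step follows the ring as such or its ring nitrogen remains open, and phenyl on the same nitrogen would separate the two. The primary amine or an ethyl group would show how clearance changes with smaller substituents.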